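A few compounds are considered here, and "the series" means these few. Any claim that something is new, unique, unknown or untested is made for them only; others in the source may bear on it.

Measured compounds so far:
compound 1 `O=C(Nc1cccc(-c2oc3cc(-c4ccc(F)cc4)ccc3c(=O)c2O)c1)c1ccc(F)cc1`: 16000 nM
compound 2 `O=C(Nc1cccc(-c2oc3cc(-c4ccc(F)cc4)ccc3c(=O)c2O)c1)c1ccc(F)cc1F`: 11200 nM
compound 3 `Cc1cccc(C(=O)Nc2cccc(-c3oc4cc(-c5ccc(F)cc5)ccc4c(=O)c3O)c2)c1`: 2840 nM

All three numbers come from a functional assay on MDA-MB-231 cells (Homo sapiens) for antiproliferative activity, read by CCK-8 assay, with a stated time of 72 h; on this read-out lower numbers stand for stronger inhibition and higher numbers for weaker inhibition. On these values compound 3 stands lowest of the three: the step of a 5.6-fold lower number from compound 1 to compound 3 (0.75 log units; beyond the scatter) and the step of a 3.9-fold lower number from compound 2 to compound 3 (0.60 log units; beyond the scatter) both lie beyond the scatter, while the step of a 1.4-fold lower number from compound 1 to compound 2 (0.15 log units; within the scatter) does not.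

Compound 4 `O=C(Nc1cccc(-c2oc3cc(-c4ccc(F)cc4)ccc3c(=O)c2O)c1)c1ccc(Cl)nc1` is not yet measured. Against compound 3 the change is 6-chloropyridin-3-yl in place of 3-methylphenyl on a carbonyl carbon. The two steps that bear on it are the ones that swap the aryl group on the carbonyl carbon: from compound 1 to compound 3 and from compound 2 to compound 3, each a modest gain on going to 3-methylphenyl from a halogenated phenyl. Compound 4 carries a chlorine-bearing aromatic ring rather than the 3-methylphenyl, so it is expected to sit nearer the halogenated analogues, compound 1 and compound 2, than to compound 3. The estimated step of a 2.8-fold higher number from compound 3 to compound 4 (0.45 log units; beyond the scatter) is expected to be a modest rise in this assay. Compound 4 is therefore estimated at 8000 nM, with a range from 2500 nM to 25000 nM.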

Compound 4, half-maximal inhibitory concentration: 1760 nM
Compound 4: the middle estimate sits 4.5-fold (0.66 log units) above what was measured, outside the stated range (below it).
By their numbers in this assay, from the lowest: compounds 4 and 3 (each within the scatter of the next); then compounds 2 and 1 (each within the scatter of the next).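

In this assay, a chlorine-bearing ring on the carbonyl carbon is compatible with a low number, unlike the fluorinated phenyl groups of compound 1 and compound 2: the steps of a 6.4-fold lower number from compound 2 to compound 4 (0.80 log units; beyond the scatter) and a 9.1-fold lower number from compound 1 to compound 4 (0.96 log units; beyond the scatter) are both beyond the scatter. The step of a 1.6-fold lower number from compound 3 to compound 4 (0.21 log units; within the scatter) is within the scatter, so 3-methylphenyl and 6-chloropyridin-3-yl cannot be ordered at this position, and 3-methylphenyl is not alone in giving a low number here. No evidence on the cause of these steps is at hand.

The compounds shown do not separate the ring nitrogen from the chlorine, as 6-chloropyridin-3-yl brings both together. Open, on these data alone, is how pyridin-3-yl without chlorine, 6-methylpyridin-3-yl or 6-aminopyridin-3-yl would behave on the same carbonyl carbon.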